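From chloro to bromo on compound 3

This account rests on a few compounds, and the source may have more. Where it says the series, first, only, none or still open, it means among the compounds named here.

Values in a functional assay on HeLa cells (Homo sapiens) for antiproliferative activity, read by cell counting, with a stated time of 72 h (a lower number here means a stronger inhibitor, a higher number a weaker inhibitor), are:
Compound 1 `C#C[C@@]1(O)[C@@H](CO)O[C@@H](n2cnc3c(-c4ccc(OC)cc4)ncnc32)[C@@H]1O` gives > 250000 nM as a limit of the assay, not a number
Compound 2 `C#C[C@@]1(O)[C@@H](CO)O[C@@H](n2cnc3c(-c4ccc(Cl)cc4)ncnc32)[C@@H]1O` gives 170000 nM
Compound 3 `C#C[C@@]1(O)[C@@H](CO)O[C@@H](n2cc(Cl)c3c(Cl)ccnc32)[C@@H]1O` gives 6300 nM

Compound 3 holds the lower of the two actual numbers (6300 nM), while compound 2 stands higher (170000 nM). A lower number means a stronger inhibitor.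

Compound 4 `C#C[C@@]1(O)[C@@H](CO)O[C@@H](n2cc(Br)c3c(Cl)ccnc32)[C@@H]1O` differs from compound 3 by a single swap (bromo in place of chloro on an aromatic carbon): bromo in place of chloro on an aromatic carbon. Among the compounds with values here, only one measured step offers any guide, the change of chloro in place of methoxy (an at least 1.4-fold lower number from compound 1 to compound 2 (0.16 log units; that floor lies within the scatter)). That step sits on a different core, involves no bromo, and its floor lies within the scatter, so it says little about this swap. Within the data shown here, with no measured step pointing either way, no change beyond the scatter is expected in this assay, in either direction. The expected change is a 1.1-fold lower number from compound 3 to compound 4 (0.06 log units; within the scatter) in this estimate. For compound 4 the expected value is 5500 nM, with an estimated range from 2000 nM to 15000 nM in repeated measurements.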

Compound 4, half-maximal inhibitory concentration: 890 nM
The estimate for compound 4 lay 6.2-fold (0.79 log units) above the measured number, outside the stated range (below it).
By their numbers in this assay, from the lowest: compound 4; then compound 3; then compound 2. At a limit, above all of these: compound 1.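

In this assay bromo in place of chloro on this aromatic carbon of the five-membered ring gives a 7.1-fold lower number from compound 3 to compound 4 (0.85 log units; beyond the scatter) and, unlike the earlier step, whose floor lay within the scatter, this one clearly lies beyond it. The change is small on paper: one heavy atom leaves and one enters, neither group has hydrogen-bond donors or acceptors, and neither carries a net charge, yet the activity at this position still responds to the swap. Nothing measured for these compounds explains why this swap has an effect of this size.

The compounds shown leave open whether iodo, methyl, a nitrile or an amine at this same place would lower the number further or raise it. On these data alone, this step also rests on a single pair, so whether bromo would have a similar effect on the core of compound 2 remains unknown.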